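This account rests on a few compounds, and the source may have more. Where it says the series, first, only, none or still open, it means among the compounds named here.

Compound 1 `CN1CCN(c2nc(Nc3ccc(C#N)c(C(F)(F)F)c3)nc(Oc3ccnc4ccccc34)n2)CC1` gives in a functional assay on DU-145 cells (Homo sapiens) for cytotoxicity, read by sulforhodamine B assay, with a stated time of 48 h (on this read-out higher numbers stand for lower toxicity in this test and lower numbers for higher toxicity in this test), a value of > 100000 nM, which is a limit of the assay and not a number.
Compound 2 `N#Cc1ccc(Nc2nc(Oc3ccnc4ccccc34)nc(N3CCN(c4cccc(C(F)(F)F)c4)CC3)n2)cc1C(F)(F)F` gives in this assay a value of > 100000 nM, again a limit of the assay.
Compound 3 `COc1ccc(N2CCN(c3nc(Nc4ccc(C#N)c(C(F)(F)F)c4)nc(Oc4ccnc5ccccc45)n3)CC2)cc1` gives in this assay a value of > 100000 nM, once more a limit of the assay.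

Compound 3 therefore stands at the limit of > 100000 nM in this assay, at which 3 of the 3 values shown sit. Within the data shown here, no measured compound in this set shows a readable number, so none of them can be called more or less toxic than another.

The step under study leads to compound 4 `N#Cc1ccc(Nc2nc(Oc3ccnc4ccccc34)nc(N3CCN(c4ncccn4)CC3)n2)cc1C(F)(F)F`, with the change (pyrimidin-2-yl in place of 4-methoxyphenyl on an amine nitrogen in a ring). Among the measured compounds shown here, three measured steps touch the same position on the shared core, each replacing the group on the amine nitrogen in the ring: a step that the two limits leave unreadable from compound 1 to compound 2, a step that the two limits leave unreadable from compound 1 to compound 3 and a step that the two limits leave unreadable from compound 2 to compound 3. All three are unreadable, because both ends sit at the limit, so they give neither size nor direction for a change at this position.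

On this basis compound 4 is expected to remain at the limit as well, with an estimated value of 150000 nM in this assay and a range from 50000 nM to 500000 nM, which is expected to mean a step that the limit leaves unreadable from compound 3 to compound 4.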

Compound 4, concentration lethal to 50% of the cells: > 100000 nM
Compound 4: a limit, no number (the forecaster's own chance of this, stated with the estimate: 80%); the middle value is on the limit's open side.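

In this assay compound 4 gives > 100000 nM and this is a limit of the assay, not a number. The steps to compound 4 from compound 1, compound 2 and compound 3 therefore cannot be read: the limit of > 100000 nM in this assay, at which 4 of the 4 values shown sit.

The compounds shown leave open whether any group on the amine nitrogen in the ring gives a readable value in this test.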